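Dropping the azetidin-1-yl group: compound 3 to compound 4

The source may hold more compounds than are shown below. What is called first, only, known or untested is meant among the compounds shown, and "the series" means these compounds.

In an in vitro functional assay on HEK285-7 cells for antagonist activity at prostaglandin D2 receptor 2 (Homo sapiens), read by BRET and beta-arrestin recruitment (a lower number here means a smaller maximal response, a higher number a larger maximal response), compound 1 `O=C(O)Cc1sc(COc2ccc(Cl)cc2)nc1-c1ccc(Cl)cc1` gives 50%. Compound 2 `O=C(O)Cc1sc(Cc2ccccc2)nc1-c1ccc(Cl)cc1` gives 50%. Within the data shown here, their only measured step, no change at the digits printed from compound 1 to compound 2 (within the scatter), alters the saturated chain carbon and not the six-membered aromatic ring with 1 nitrogen. Compound 3 `O=C(O)Cc1sc(C(c2ccc(F)cc2)c2ccc(F)cc2)nc1-c1ccnc(N2CCC2)c1` gives 80%, the highest of the three, with both others beyond the scatter below it. Compound 4 `O=C(O)Cc1sc(C(c2ccc(F)cc2)c2ccc(F)cc2)nc1-c1ccncc1` differs from compound 3 by hydrogen in place of azetidin-1-yl on an aromatic carbon. Among the measured compounds shown here, no measured step touches this position, so the expectation rests on compound 3 alone and carries little support. The estimated step of a number 10 percentage points lower from compound 3 to compound 4 (within the scatter) is expected to be small, a possible drop toward the other two. Compound 4 is therefore expected at 70%, between 50% and 90%.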

Compound 4, largest response reached (reported as efficacy), in percent of the reference or control that the assay uses: 80%
Estimate against measurement, compound 4: 10 percentage points below, and the stated range covers the measured number.
By their numbers in this assay, from the lowest: compounds 1 and 2 (each within the scatter of the next); then compounds 3 and 4 (each within the scatter of the next).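

In this assay, among these compounds, the step of no change at the digits printed from compound 3 to compound 4 (within the scatter) is the first reading at this position on the six-membered aromatic ring with 1 nitrogen. The earlier step, at the saturated chain carbon, could not show that azetidin-1-yl can give way to hydrogen here with the maximal response unchanged within the scatter. No measurement on hand accounts for this result. Still open, from the compounds shown here alone, is whether a dimethylamino group, a methoxy group or a chlorine atom at this position would read the same. A single pair also leaves open whether the same exchange reads alike with other groups elsewhere on the core.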